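This account rests on a few compounds, and the source may have more. Where it says the series, first, only, none or still open, it means among the compounds named here.

Of the compounds shown here, three have been measured in a functional assay (strain AB) with Danio rerio as the target, read by microscopy, with a stated time of 1 h; a lower number here means that less compound is needed, a higher number that more compound is needed for the effect. Compound 1 (`CC(C)(C)OC(=O)CCC[N+]1(C)CCc2c(sc(NC(=O)Nc3ccc(Cl)cc3)c2C(N)=O)C1`) gives 250 nM and compound 2 (`C[N+]1(CC2CCC2)CCc2c(sc(NC(=O)Nc3ccc(Cl)cc3)c2C(N)=O)C1`) gives 210 nM. Going by the values given here, the only measured step is a 1.2-fold lower number from compound 1 to compound 2 (0.08 log units; within the scatter). Compound 3 (`CC(C)(C)OC(=O)N1CCc2c(sc(NC(=O)Nc3ccc(Cl)cc3)c2C(N)=O)C1`) gives only a limit, > 25000 nM, which is the limit of > 25000 nM in this assay, at which 1 of the 3 values shown sits.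

Compound 4 (`COCCCN1CCc2c(sc(NC(=O)Nc3ccc(Cl)cc3)c2C(N)=O)C1`) has 3-methoxypropyl in place of tert-butoxycarbonyl on an amine nitrogen in a ring. Among the compounds with values here, no measured step starts from compound 3, so the guide is indirect: compound 1 at 250 nM and compound 2 at 210 nM both carry a saturated chain on that nitrogen. Both also carry a methyl group there, which compound 4 lacks, so the expectation stays loose. A large move towards a lower number is expected, estimated as an at least 12-fold lower number from compound 3 to compound 4 (1.09 log units; beyond the scatter). For compound 4 the estimate is 2000 nM, with an expected range of 300 nM to 15000 nM.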

Compound 4, half-maximal effective concentration: 2400 nM
The estimate for compound 4 lay 1.2-fold (0.08 log units) below the measured number; measured number inside the range.
By their numbers in this assay, from the lowest: compounds 2 and 1 (each within the scatter of the next); then compound 4. At a limit, above all of these: compound 3.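

In this assay, this amine nitrogen in a ring tolerates change with a large effect: an at least 10-fold lower number from compound 3 to compound 4 (1.01 log units; beyond the scatter) comes with 3-methoxypropyl in place of tert-butoxycarbonyl. Neither group has a ring or a net charge, so a readable number at this position does not depend on either group carrying a charge. The value of compound 3 is a limit, so the full size of this step stays unknown: the limit of > 25000 nM in this assay, at which 1 of the 4 values shown sits.

Open, on these data alone, is whether a longer chain on this nitrogen moves the number further. Also open, as far as these compounds go, is what an amine or a carboxylic acid in place of the methoxy end would do.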